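Notes on chain homologation in the series

A few compounds are considered here, and "the series" means these few. Any claim that something is new, unique, unknown or untested is made for them only; others in the source may bear on it.

Measured so far:
compound 1 `CCCCCCCCOC(=O)NC(=O)Oc1c(C(C)C)cccc1C(C)C`: in an assay on microsomes from intestine for inhibition of acyl-CoA:cholesterol acyltransferase (Oryctolagus cuniculus) (on this read-out lower numbers stand for stronger inhibition and higher numbers for weaker inhibition), compound 1 gives 250 nM
compound 2 `CCCCCCCCCCOC(=O)NC(=O)Oc1c(C(C)C)cccc1C(C)C`: in this assay compound 2 gives 74 nM

Compound 2 holds the lowest number of the two measured; its nearest neighbour is compound 1, and the step of a 3.4-fold lower number from compound 1 to compound 2 (0.53 log units; beyond the scatter) lies beyond the scatter, so compound 2 counts as the stronger of the pair on this read-out.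

Compound 3 `CCCCCCCCCCCOC(=O)NC(=O)Oc1c(C(C)C)cccc1C(C)C` is the next member: methyl in place of hydrogen on a saturated chain carbon, ten or more bonds along the chain from an oxygen next to a carbonyl group. Among the measured compounds shown here, the only measured step that bears on this is the one from compound 1 to compound 2, which added two chain carbons at the same end and produced a modest gain; the present change adds one carbon further out. Direction is therefore expected to be the same, toward lower numbers, but the size is expected to be smaller than the step already seen and may fall within the scatter.

Compound 3 is expected to give about 50 nM in this assay, within 20 nM to 130 nM. The expected step is a 1.5-fold lower number from compound 2 to compound 3 (0.17 log units; within the scatter).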

Compound 3, half-maximal inhibitory concentration: 140 nM
Compound 3: middle estimate off by 2.8-fold (0.45 log units), on the low side; measured number above the stated range.
By their numbers in this assay, from the lowest: compounds 2, 3 and 1 (each within the scatter of the next, the first and the last beyond it).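

Putting methyl in place of hydrogen on a saturated chain carbon, ten or more bonds along the chain from an oxygen next to a carbonyl group, gives a 1.9-fold higher number from compound 2 to compound 3 (0.28 log units; within the scatter) in this assay and so adds no resolved gain at this chain end. The earlier lengthening gave a separation beyond the scatter, whereas this further carbon leaves compound 3 unresolved from compound 2, so compound 3 goes against any claim of a steady gain with chain length. Set against the shorter chain, the series gives a 1.8-fold lower number from compound 1 to compound 3 (0.25 log units; within the scatter) and compound 3 is also unresolved from compound 1, even though compound 1 and compound 2 stand apart beyond the scatter. No supporting measurement is available to account for this result.

As far as these compounds go, with three neighbouring chain lengths, it remains open whether the response in this assay levels off near compound 2 and compound 3, turns upward, or alternates from one chain length to the next. A dodecyl or longer chain would help to separate these readings, and a branched chain or a chain ending in a hydroxyl group or a carboxylic acid would show how much change this far out along the chain can be accommodated.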